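The source may report more compounds than this note shows. Statements on the series, on what has been measured and on what is new or still open speak of the compounds shown alone.

Compound 1 `CCCCCCc1cc2cn(Cc3cn(-c4ccccc4F)nn3)c(=O)nc2o1` gives > 100000 nM in a functional assay on SW-620 cells (Homo sapiens) for antiproliferative activity, read by MTT assay, with a stated time of 72 h (on this read-out higher numbers stand for weaker inhibition and lower numbers for stronger inhibition), a figure that is a limit of the assay rather than a number.
Compound 2 `CCCCCCC#Cc1c(CCCCCC)oc2nc(=O)n(Cc3cn(Cc4ccccc4)nn3)cc12` gives 32600 nM in this assay.

Compound 2 thus holds the only actual number shown; the other value is a limit, as the limit of > 100000 nM in this assay, at which 1 of the 2 values shown sits, describes. Compound 3 `CCCCCCc1cc2cn(Cc3cn(Cc4ccccc4)nn3)c(=O)nc2o1` differs from compound 2 by hydrogen in place of oct-1-yn-1-yl on an aromatic carbon. Among the compounds with values here, no measured pair shows a change of this kind, so the size of the step in this assay is uncertain; a weakening beyond the usual scatter seems more likely than a gain, and the result may again be only a limit. Compound 3 is therefore expected at 100000 nM, between 30000 nM and 300000 nM. That amounts to an expected step of a 3.1-fold higher number from compound 2 to compound 3 (0.49 log units; beyond the scatter).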

Compound 3, half-maximal inhibitory concentration: 93500 nM
For compound 3 the middle estimate is 1.1-fold (0.03 log units) above the measured one, and the stated range covers the measured number.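

The oct-1-yn-1-yl group on this aromatic carbon has a measurable effect: replacing it with hydrogen gives a 2.9-fold higher number from compound 2 to compound 3 (0.46 log units; beyond the scatter) in this assay, a modest loss of activity. Putting benzyl in place of 2-fluorophenyl on the aromatic nitrogen gives an at least 1.0-fold lower number from compound 1 to compound 3 (0.02 log units; that floor lies within the scatter), so this change shows no clear effect. Compound 1 gives a limit rather than a number: the limit of > 100000 nM in this assay, at which 1 of the 3 values shown sits.

As far as these compounds go, it remains open whether the triple bond matters or only the presence of a chain at this carbon. An octyl chain or an amine there would help separate the two.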